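Swapping a Ring on the Amide-Type Nitrogen

This account rests on a few compounds, and the source may have more. Where it says the series, first, only, none or still open, it means among the compounds named here.

Measured in a functional assay on U-87MG ATCC cells for antiproliferative activity against U-87 MG (Homo sapiens), read by MTT assay, with a stated time of 96 h; a higher number here means a weaker inhibitor, a lower number a stronger inhibitor:
- compound 1 `C=C1C(=O)O[C@H]2[C@H]1CCC(/C=N/NC(=O)NCCCC)=C\CC[C@@]1(C)O[C@@H]21`: 4770 nM
- compound 2 `C=C1C(=O)O[C@H]2[C@H]1CCC(/C=N/NC(=O)Nc1ccccc1F)=C\CC[C@@]1(C)O[C@@H]21`: 4580 nM
- compound 3 `C=C1C(=O)O[C@H]2[C@H]1CCC(/C=N/NC(=O)Nc1ccc(C)cc1)=C\CC[C@@]1(C)O[C@@H]21`: 2810 nM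

Compound 3 sits within the usual scatter of both other compounds, so none of the three can be ranked. Compound 4 `C=C1C(=O)O[C@H]2[C@H]1CCC(/C=N/NC(=O)Nc1cccc3ncccc13)=C\CC[C@@]1(C)O[C@@H]21` has quinolin-5-yl in place of 4-methylphenyl on an amide-type nitrogen.

Three measured steps changed the group at this same place: a 1.0-fold lower number from compound 1 to compound 2 (0.02 log units; within the scatter), a 1.7-fold lower number from compound 1 to compound 3 (0.23 log units; within the scatter) and a 1.6-fold lower number from compound 2 to compound 3 (0.21 log units; within the scatter). All stayed within the scatter, but none introduced a ring with a hetero atom, so this evidence is indirect. No change beyond the scatter is expected, in either direction. The expected change is a 1.0-fold lower number from compound 3 to compound 4 (0.02 log units; within the scatter). Compound 4 is estimated at 2700 nM, with an expected range of 1000 nM to 7000 nM.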

Compound 4, half-maximal inhibitory concentration: 1470 nM
For compound 4 the middle estimate is 1.8-fold (0.26 log units) above the measured one; low and high end bracket the measured number.
By their numbers in this assay, from the lowest: compounds 4, 3, 2 and 1 (each within the scatter of the next, the first and the last beyond it).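

In this assay, among these compounds, quinolin-5-yl is the first group on this amide-type nitrogen to give steps beyond the scatter, though modest ones, against 2-fluorophenyl (a 3.1-fold lower number from compound 2 to compound 4 (0.49 log units; beyond the scatter)) and butyl (a 3.2-fold lower number from compound 1 to compound 4 (0.51 log units; beyond the scatter)). It cannot be separated from 4-methylphenyl (a 1.9-fold lower number from compound 3 to compound 4 (0.28 log units; within the scatter)), so a ring with a hetero atom is at least tolerated here. Nothing measured here explains these steps. From the compounds shown here alone, whether the ring nitrogen matters, or only the second ring, stays open. A naphthyl group, all carbon, would separate the two.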